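From Chloro to Fluoro: Expected Cytotoxicity of Compound 4

The source may hold more compounds than are shown below. What is called first, only, known or untested is meant among the compounds shown, and "the series" means these compounds.

Measured compounds:
compound 1, `O=C(COc1cccc2ccccc12)N/N=C/c1ccc(Cl)cc1` — 100 ug/mL
compound 2, `COc1ccc(/C=N/NC(=O)COc2cccc3ccccc23)cc1O` — 27.7 ug/mL
compound 3, `COc1cc(/C=N/NC(=O)COc2cccc3ccccc23)cc(OC)c1O` — 52.8 ug/mL

Of the compounds shown here, three have been tested in an ADME assay on HEL cells (Homo sapiens) for cytotoxicity; on this read-out lower numbers stand for higher toxicity in this test and higher numbers for lower toxicity in this test. All three share the same core and differ only in the substituted aromatic ring at the far end. Compound 1 gives 100 ug/mL, the highest number of the three, which in this assay means the lowest toxicity. Compound 3 gives 52.8 ug/mL, a gap to compound 1 that stays within the usual scatter, so the two cannot be ranked. Compound 2 gives 27.7 ug/mL, and here the gap to compound 1 lies beyond the scatter, so compound 2 is the more toxic of that pair.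

Compound 4, `O=C(COc1cccc2ccccc12)N/N=C/c1ccc(F)cc1`, has not yet been measured. It differs from compound 1 in one place: fluoro in place of chloro on an aromatic carbon. For the measured compounds named here, no measured pair in this set shows what such a swap does in this assay, so the expectation rests on the small size of the change alone. The expected step is a 1.1-fold lower number from compound 1 to compound 4 (0.05 log units; within the scatter), meaning no change beyond the scatter in either direction. Compound 4 is therefore estimated at 90 ug/mL, with a range from 45 ug/mL to 180 ug/mL.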

Compound 4, half-maximal cytotoxic concentration: 71.6 ug/mL
Compound 4: middle estimate off by 1.3-fold (0.10 log units), on the high side, within the range that was stated.
By their numbers in this assay, from the lowest: compounds 2, 3, 4 and 1 (each within the scatter of the next, the first and the last beyond it).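

For the compounds shown here, this is the first pair in the set that differs in one place only, so it gives the first direct reading of a single change. In this assay, going from 4-chlorophenyl to 4-fluorophenyl gives a 1.4-fold lower number from compound 1 to compound 4 (0.15 log units; within the scatter), which means that on this aromatic carbon, para to a large group, fluoro and chloro cannot be told apart, and neither compound can be ranked as the more toxic. Nothing available here offers a measured reason for this result.

What this single pair leaves open is how far the tolerance at this position extends: it compares only two halogens, so a plain hydrogen, an amine or a carboxylic acid in the same place could behave quite differently in this test. Compound 2 and compound 3 each differ from compound 1 in more than one place, so their values cannot show what any one of their ring groups contributes, and a compound carrying just one of those groups would be needed to separate them.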